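This account rests on a few compounds, and the source may have more. Where it says the series, first, only, none or still open, it means among the compounds named here.

Compound 1 `Brc1cccc(Cc2nnc(Cn3nnc4ccccc43)o2)c1`: > 100000 nM
Compound 2 `Fc1cccc(Cc2nnc(Cn3nnc4ccccc43)o2)c1`: > 100000 nM

In an ADME assay on cells (Macrophage, Homo sapiens) for inhibition (a higher number here means that more compound is tolerated, a lower number that less compound is tolerated), compound 2 gives > 100000 nM, which is a limit of the assay and not a number. Compound 1 gives > 100000 nM, which is also a limit. All the evidence so far therefore comes down to the limit of > 100000 nM in this assay, at which 2 of the 2 values shown sit.

Compound 3 `COc1ccc(Cc2nnc(Cn3nnc4ccccc43)o2)cc1` has 4-methoxyphenyl in place of 3-fluorophenyl on a saturated chain carbon bound to an aromatic carbon. Going by the values given here, the only measured step, a step that the two limits leave unreadable from compound 1 to compound 2, has no readable size to carry over, and it shows no direction either. The expectation therefore rests on compound 2 with its limit of > 100000 nM. The expected result is a number no higher from compound 2 to compound 3 (the limit leaves the size open), with no change beyond the usual scatter in this assay. Compound 3 is estimated at 100000 nM, with an expected range of 40000 nM to 200000 nM.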

Compound 3, half-maximal cytotoxic concentration: > 100000 nM
Compound 3: a limit, no number; the forecaster's own chance of this, stated with the estimate: 80%; the middle value sits exactly at the limit.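

In this assay compound 3 gives > 100000 nM as a limit and not a number, so its steps from compound 1 and from compound 2 cannot be read. The compounds shown leave open at what concentration any of them harms these cells, and whether their differing groups change that concentration.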